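The source may hold more compounds than are shown below. What is called first, only, known or untested is meant among the compounds shown, and "the series" means these compounds.

Measured in a functional assay on brain (Rattus norvegicus, strain Wistar) for inhibition; on this read-out higher numbers stand for weaker inhibition and lower numbers for stronger inhibition:
- compound 1 `CCCCOc1ccc(-c2c(C)[nH]c(=O)n2C)cc1`: 5100 nM
- compound 2 `COc1ccc(-c2c(C)[nH]c(=O)n2C)cc1`: 147000 nM
- compound 3 `CCCCCc1ccc(-c2c(C)[nH]c(=O)n2C)cc1`: 5900 nM

Compound 3, at 5900 nM, sits level with compound 1 within the scatter, as a 1.2-fold higher number from compound 1 to compound 3 (0.06 log units; within the scatter) shows. It lies far under compound 2, with a 25-fold lower number from compound 2 to compound 3 (1.40 log units; beyond the scatter). The next compound, compound 4 `Cc1[nH]c(=O)n(C)c1-c1ccc(C2CCCCC2)cc1`, carries cyclohexyl in place of pentyl on an aromatic carbon.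

For the measured compounds named here, no measured step tests a ring at this place, so the evidence is indirect. The a 1.2-fold higher number from compound 1 to compound 3 (0.06 log units; within the scatter) shows that exchanging butoxy for pentyl left the number within the scatter. The two large steps, a 29-fold higher number from compound 1 to compound 2 (1.46 log units; beyond the scatter) and a 25-fold lower number from compound 2 to compound 3 (1.40 log units; beyond the scatter), both involve methoxy, a group much shorter than the others, and cyclohexyl resembles pentyl more than methoxy in its count of carbons. In this assay, from the compounds shown here alone, a change beyond the scatter is therefore not expected, though the direction remains open. The expected step is a 1.3-fold lower number from compound 3 to compound 4 (0.12 log units; within the scatter). For compound 4 the estimated value is 4500 nM, with an expected range from 1500 nM to 14000 nM.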

Compound 4, half-maximal inhibitory concentration: 10000 nM
Beside the measured number, compound 4's estimate is 2.2-fold (0.35 log units) below it; low and high end bracket the measured number.
By their numbers in this assay, from the lowest: compounds 1, 3 and 4 (each within the scatter of the next); then compound 2.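

In this assay, for the compounds shown here, a ring now stands at this place for the first time, and cyclohexyl in place of pentyl on an aromatic carbon leaves the number within the scatter (a 1.7-fold higher number from compound 3 to compound 4 (0.23 log units; within the scatter)). The same holds for cyclohexyl in place of butoxy (a 2.0-fold higher number from compound 1 to compound 4 (0.29 log units; within the scatter)), while the large step from the methoxy compound remains (a 15-fold lower number from compound 2 to compound 4 (1.17 log units; beyond the scatter)), so among these compounds, the open chains and a six-membered non-aromatic ring of carbon only cannot be told apart, and only compound 2 stands apart. No supporting data bear on why this position accepts both shapes.

Still open, from the compounds shown here alone, is where the number would fall with a group of intermediate length, such as ethoxy. Going by these compounds, it is equally open whether a longer chain, an amine or a carboxylic acid at this place would keep the number near that of compound 4.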